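The source may hold more compounds than are shown below. What is called first, only, known or untested is meant among the compounds shown, and "the series" means these compounds.

Measured so far:
compound 1 `CC(C)COc1ccc(NC(=O)CCCCCCCSc2nnc(Cc3nn(C)c(=O)c4ccccc34)n2C)cc1` gives 4800 nM in an assay on isolated protein (Mus musculus) for inhibition of IL15-IL15 receptor (Homo sapiens), read by resazurin assay, with stated times of 30 min and 2.5 days; on this read-out lower numbers stand for stronger inhibition and higher numbers for weaker inhibition
compound 2 `Cn1c(Cc2nn(C)c(=O)c3ccccc23)nnc1SCCCCCCCC(=O)Nc1ccc(O)cc1` gives > 30000 nM in this assay

The value of compound 2 is a limit of the assay, not a number. Within the data shown here, the single measured step, an at least 6.2-fold higher number from compound 1 to compound 2 (0.79 log units; beyond the scatter), removed the isobutyl and left the hydroxyl; it does not cover the change to compound 3 `Cn1c(Cc2nn(C)c(=O)c3ccccc23)nnc1SCCCCCCCC(=O)Nc1ccc(Cl)cc1Cl`, which is 2,4-dichlorophenyl in place of 4-hydroxyphenyl on an amide-type nitrogen. Compound 2 sits at the limit of > 30000 nM in this assay, at which 1 of the 2 values shown sits, so any step from it can only appear as a lower number. Compound 1, also lacking the hydroxyl, gives 4800 nM. Compound 3 is therefore expected to come back into a measurable range, a step of an at least 3.7-fold lower number from compound 2 to compound 3 (0.57 log units; beyond the scatter). The estimate for compound 3 is 8000 nM, between 2000 nM and 30000 nM.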

Compound 3, half-maximal inhibitory concentration: 1900 nM
Compound 3: middle estimate off by 4.2-fold (0.62 log units), on the high side, and the stated range ends above it.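

In this assay compound 2 gives > 30000 nM, which is a limit of the assay and not a number. Even so, placing 2,4-dichlorophenyl on the amide-type nitrogen instead of 4-hydroxyphenyl gives an at least 15-fold lower number from compound 2 to compound 3 (1.19 log units; beyond the scatter), so this position can move the read-out by a large step. The same group in place of 4-(isobutoxy)phenyl gives a 2.5-fold lower number from compound 1 to compound 3 (0.40 log units; beyond the scatter), so an isobutyl ether is not needed here for a measurable value. Still open, as far as these compounds go, is whether a single chlorine would do as well, and how an amine or a carboxylic acid on that phenyl ring would read.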